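A few compounds are considered here, and "the series" means these few. Any claim that something is new, unique, unknown or untested is made for them only; others in the source may bear on it.

In a functional assay on aorta for inhibition of Voltage-dependent L-type calcium channel subunit alpha-1C (Rattus norvegicus) (a lower number here means a stronger inhibitor, a higher number a weaker inhibitor), compound 2 `CC(C)(C)c1cc(C2SCC(=O)N2CCCN)cc(C(C)(C)C)c1O` gives 4400 nM, the highest number among the three measured compounds. Compound 1 `CN(CCCN1C(=O)CSC1c1cc(C(C)(C)C)c(O)c(C(C)(C)C)c1)CC1CC1` gives 1200 nM and compound 3 `COc1cc2c(cc1OC)CN(CCCN1C(=O)CSC1c1cc(C(C)(C)C)c(O)c(C(C)(C)C)c1)CC2` gives 200 nM. Compound 4 `CN(C)CCCN1C(=O)CSC1c1cc(C(C)(C)C)c(O)c(C(C)(C)C)c1` differs from compound 2 by dimethylamino in place of amino on a saturated chain carbon, three bonds along the chain from an amide-type nitrogen in a ring. Going by the values given here, one measured step bears on this change: a 3.7-fold higher number from compound 1 to compound 2 (0.56 log units; beyond the scatter), where amino in place of (cyclopropylmethyl)(methyl)amino gave the weaker inhibitor. Compound 3 also shows a clearly lower number than compound 2. Putting dimethylamino in place of amino is therefore expected to move the number back down, by a step of about a 2.9-fold lower number from compound 2 to compound 4 (0.47 log units; beyond the scatter). Compound 4 is estimated to give 1500 nM, with a range from 600 nM to 4000 nM.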

Compound 4, half-maximal inhibitory concentration: 1500 nM
Compound 4: the middle estimate sits on the measured number at the digits printed, and the stated range covers the measured number.
By their numbers in this assay, from the lowest: compound 3; then compounds 1 and 4 (each within the scatter of the next); then compound 2.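

Dimethylamino in place of amino, at this place on the chain, is enough by itself to give a clearly stronger inhibitor in this assay: a 2.9-fold lower number from compound 2 to compound 4 (0.47 log units; beyond the scatter). Hydrogen in place of cyclopropyl on a saturated chain carbon bound to an amine nitrogen makes no readable difference: a 1.3-fold higher number from compound 1 to compound 4 (0.10 log units; within the scatter). Nothing shown here explains the effect of dimethylamino.

On these data alone, whether methylamino, carrying a single methyl, would read like amino or like dimethylamino remains open. So does the effect of a longer chain than 3-(dimethylamino)propyl.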